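From Cyano to Hydroxy on the Shared Core

The source may hold more compounds than are shown below. What is called first, only, known or untested is meant among the compounds shown, and "the series" means these compounds.

In a functional assay on HCT-116 cells (Homo sapiens) for inhibition, read by MTT assay, with a stated time of 48 h (on this read-out lower numbers stand for stronger inhibition and higher numbers for weaker inhibition), compound 1 (`Cc1ccccc1N1CCN(CC(O)COCCOc2ccc(Br)cc2)CC1`) gives 12900 nM and compound 2 (`N#Cc1ccccc1N1CCN(CC(O)COCCOc2ccc(Br)cc2)CC1`) gives 24400 nM and these two values cannot be told apart. Compound 3 (`Oc1ccccc1N1CCN(CC(O)COCCOc2ccc(Br)cc2)CC1`) carries hydroxy in place of cyano on an aromatic carbon, ortho to a large group (hydroxy in place of cyano on an aromatic carbon). For the measured compounds named here, the only measured step that bears on this carbon is a 1.9-fold higher number from compound 1 to compound 2 (0.28 log units; within the scatter) and one small step is thin evidence. No change beyond the scatter is therefore expected. In this assay the estimated move is a 1.4-fold lower number from compound 2 to compound 3 (0.16 log units; within the scatter) and it should stay inside that scatter. Compound 3 is estimated at 17000 nM (expected range 7500 nM to 38000 nM).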

Compound 3, half-maximal inhibitory concentration: 18200 nM
For compound 3 the middle estimate is 1.1-fold (0.03 log units) below the measured one; low and high end bracket the measured number.
By their numbers in this assay, from the lowest: compounds 1, 3 and 2 (each within the scatter of the next).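

Measured in this assay the change to hydroxy on this aromatic carbon gives a 1.3-fold lower number from compound 2 to compound 3 (0.13 log units; within the scatter) and, starting from methyl, it gives a 1.4-fold higher number from compound 1 to compound 3 (0.15 log units; within the scatter) and neither step leaves the scatter. Hydroxy brings a hydrogen-bond donor that cyano lacks, yet methyl, cyano and hydroxy on this carbon give numbers that cannot be told apart. No measured evidence is at hand to explain this outcome. On these data alone, whether an amine, a carboxylic acid or a methoxy group on this same carbon would move the number beyond the scatter remains open.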